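From methoxy to benzyloxy on a shared core

The source may hold more compounds than are shown below. What is called first, only, known or untested is meant among the compounds shown, and "the series" means these compounds.

Measured so far in a functional assay on blood (Homo sapiens) for inhibition; a higher number here means a weaker inhibitor, a lower number a stronger inhibitor
- compound 1 `COC(=O)COc1ccc(OCc2ccc3ccccc3n2)cc1C1(c2ccccc2)CC2CCC1C2` gives 290 nM
- compound 2 `CCOC(=O)CCCOc1ccc(OCc2ccc3ccccc3n2)cc1C1(c2ccccc2)CC2CCC1C2` gives 150 nM
- compound 3 `COc1ccc(OCc2ccc3ccccc3n2)cc1C1(c2ccccc2)CC2CCC1C2` gives 1100 nM

With 1100 nM compound 3 has the highest number of the three and is the weakest inhibitor here. Compound 4 `c1ccc(COc2ccc(OCc3ccc4ccccc4n3)cc2C2(c3ccccc3)CC3CCC2C3)cc1` differs from it by phenyl in place of hydrogen on a saturated chain carbon bound to an oxygen on an aromatic ring with phenyl in place of hydrogen on a saturated chain carbon bound to an oxygen on an aromatic ring, which reads as methoxy to benzyloxy.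

Two modest measured steps at this place bear on the change, a 3.8-fold higher number from compound 1 to compound 3 (0.58 log units; beyond the scatter) and a 7.3-fold higher number from compound 2 to compound 3 (0.87 log units; beyond the scatter). In both, the number rises as hydrogen replaces a larger group. Neither compound 1 nor compound 2 carries phenyl there, so the transfer is uncertain. A modest move to a lower number is expected, with an estimated step of a 2.8-fold lower number from compound 3 to compound 4 (0.44 log units; beyond the scatter). For compound 4 the estimated value is 400 nM, with an expected range from 130 nM to 1200 nM.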

Compound 4, half-maximal inhibitory concentration: > 3000 nM
Compound 4 gave a limit, no number; the forecaster's own chance of this, stated with the estimate: 3%; middle value at least 7.5-fold (0.87 log units) away from the limit.
By their numbers in this assay, from the lowest: compounds 2 and 1 (each within the scatter of the next); then compound 3. At a limit, above all of these: compound 4.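

In this assay compound 4 gives only a limit, > 3000 nM, and not a number. A larger group at this place therefore does not always lower the number as it did in compounds 1 and 2: phenyl in place of hydrogen gives an at least 2.7-fold higher number from compound 3 to compound 4 (0.43 log units; beyond the scatter). Against the ester-bearing chains, phenyl gives an at least 10-fold higher number from compound 1 to compound 4 (1.01 log units; beyond the scatter) and an at least 20-fold higher number from compound 2 to compound 4 (1.30 log units; beyond the scatter).

The compounds shown leave open how far the number of compound 4 lies past its limit. They also leave open whether a longer chain ending in phenyl, or a carboxylic acid in place of the esters, would stay with compounds 1 and 2.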